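This account rests on a few compounds, and the source may have more. Where it says the series, first, only, none or still open, it means among the compounds named here.

In a functional assay on MCF7 cells (Homo sapiens) for antiproliferative activity, read by CCK-8 assay, with a stated time of 5 days (a lower number here means a stronger inhibitor, a higher number a weaker inhibitor), compound 1 `COc1ccc(CCc2nc3cc(-c4c(C)noc4C)ccc3n2[C@H]2CC[C@H](OC)CC2)cc1Cl` gives 5650 nM and compound 2 `COc1ccc(CCc2nc3cc(-c4c(C)noc4C)ccc3n2[C@H]2CC[C@H](O)CC2)cc1Cl` gives 2820 nM. Hydrogen in place of methyl on an oxygen on a saturated carbon separates these two, a step of a 2.0-fold lower number from compound 1 to compound 2 (0.30 log units; within the scatter). Compound 3 `COc1ccc(N2C(=O)C[C@H]2c2nc3cc(-c4c(C)noc4C)ccc3n2[C@H]2CC[C@H](OC)CC2)cc1Cl`, which carries a different side group on the shared core, gives 960 nM, the lowest of the three numbers and beyond the scatter from both others.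

Compound 4 `COc1ccc(N2C(=O)C[C@@H]2c2nc3cc(-c4c(C)noc4C)ccc3n2[C@H]2CC[C@H](OC)CC2)cc1Cl` is built from the same pieces: the two compounds have the same atoms and bonds and differ only in configuration as drawn: 2 of 3 stereo elements differ; a stereocentre at a saturated ring carbon is drawn S in compound 3 and R in compound 4; a stereocentre at a saturated ring carbon is drawn S in compound 3 and R in compound 4. The two compounds differ only in configuration as drawn, so nothing is added or removed. Within the data shown here, the one measured step swaps a group rather than a configuration, so it offers no real guide to size or direction here. Since compound 3 at 960 nM already holds the lowest number, a rise looks somewhat likelier than a further fall, though either remains possible. The expected change is a 2.1-fold higher number from compound 3 to compound 4 (0.32 log units; beyond the scatter). For compound 4 the estimate is 2000 nM, within an expected range of 300 nM to 8000 nM.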

Compound 4, half-maximal inhibitory concentration: 1990 nM
Compound 4: middle estimate off by 1.0-fold (0.00 log units), on the high side, within the range that was stated.
By their numbers in this assay, from the lowest: compound 3; then compounds 4, 2 and 1 (each within the scatter of the next, the first and the last beyond it).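

In this assay, the step of a 2.1-fold higher number from compound 3 to compound 4 (0.32 log units; beyond the scatter) is modest, yet it shows that the drawn configuration alone can move the number past the usual scatter, with no group added or removed. Among these compounds, the only earlier step, a 2.0-fold lower number from compound 1 to compound 2 (0.30 log units; within the scatter), exchanged a group on an oxygen and stayed within the scatter. This new gap can be put down to spatial arrangement, because the pair offers no other difference: the fact that compounds 3 and 4 differ only in the configuration as drawn.

Two stereocentres at saturated ring carbons change together, so the compounds shown cannot tell whether one of them accounts for the step or both contribute. Also open, from the compounds shown here alone, is whether this preference for the configuration of compound 3 would hold with another group on the shared core, such as an amine in place of the chlorine.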